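The compounds below may be only part of what the source reports. "The series", "measured", "known", "first", "only" and "open" are said of these compounds alone.

Working notes on the series

Of the compounds shown here, three on a shared core have been measured. Compound 1 `COC(=O)CC1c2ccccc2N=C(NCCCCCNC(=O)OC(C)(C)C)N1c1ccc(-c2ccccc2)cc1` gives 3830 nM in a functional assay on A549 cells (Homo sapiens) for inhibition, read by sulforhodamine B assay, with a stated time of 72 h; on this read-out lower numbers stand for stronger inhibition of growth and higher numbers for weaker inhibition of growth. Compound 2 `COC(=O)CC1c2ccccc2N=C(Nc2ccc(-c3ccccc3)cc2)N1CCCCCN` gives 2900 nM in this assay. Compound 3 `O=C(CC1c2ccccc2N=C(N2CCCCC2)N1c1ccccc1)NCc1ccc(NS(=O)(=O)c2ccc(F)cc2)cc1` gives 1930 nM in this assay, the lowest of the three numbers; its gap to compound 2 and its gap to compound 1 both lie within the scatter, so no order among the three can be read from these numbers.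

Compound 4 `CCN1C(N2CCCCC2)=Nc2ccccc2C1CC(=O)NCc1ccc(NS(=O)(=O)c2ccc(F)cc2)cc1` has not been measured. It differs from compound 3 in one place: ethyl in place of phenyl on an amine nitrogen in a ring. Among the compounds with values here, no pair of measured compounds shows this change, so there is no measured step to lean on; the three measured compounds differ from each other in several places at once and give no guide for this single substitution. Compound 4 is thus expected to show a step of a 1.3-fold higher number from compound 3 to compound 4 (0.11 log units; within the scatter), which is meant as a step no larger than the scatter, with no firm direction. The estimate for compound 4 in this assay is 2500 nM, with a range from 800 nM to 8000 nM to reflect the lack of any measured precedent for this change.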

Compound 4, concentration for 50% growth inhibition: 24500 nM
The estimate for compound 4 lay 9.8-fold (0.99 log units) below the measured number; measured number outside the range, above it.
By their numbers in this assay, from the lowest: compounds 3, 2 and 1 (each within the scatter of the next); then compound 4.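

Working notes, continued

In this assay, ethyl in place of phenyl on an amine nitrogen in a ring gives a 13-fold higher number from compound 3 to compound 4 (1.10 log units; beyond the scatter), so the group at this position has a clear bearing on the read-out, at least with the piperidin-1-yl group and the side chain of compound 3 in place. The earlier compounds shown here differ in several places at once and could not isolate this position; this matched pair does, and phenyl is the better of the two groups compared here. No measurement at hand bears on why the step is this large, and the reason stays unknown.

The change removes a six-membered aromatic ring and also reduces the heavy-atom count, so this single pair cannot separate the loss of the aromatic ring from the loss of size. Cyclohexyl, benzyl or a longer chain such as hexyl at this position would help to separate the two, and it remains open whether the step carries over to compounds with another group in place of the piperidin-1-yl group.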